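Naphthyl Attachment Point in a Pyrazoline Thiazoline Series

A few compounds are considered here, and "the series" means these few. Any claim that something is new, unique, unknown or untested is made for them only; others in the source may bear on it.

Measured compounds:
compound 1, `COc1ccc(C2=NN(C3=NC(c4ccccc4)CS3)C(c3ccc4ccccc4c3)C2)cc1`, 1860 nM
compound 2, `Clc1ccc(C2=NN(C3=NC(c4ccccc4)CS3)C(c3cccc4ccccc34)C2)cc1`, 9940 nM

The two measured compounds share a core and differ in two places, the aryl group on the unsaturated ring carbon and the naphthyl group on the saturated one. In a functional assay on HeLa cells (Homo sapiens) for inhibition, read by CCK-8 assay, with a stated time of 48 h (a higher number here means a weaker inhibitor, a lower number a stronger inhibitor), compound 1 gives 1860 nM, while compound 2 gives 9940 nM, the higher of the two numbers, with compound 1 lying beyond the scatter below it.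

Compound 3, `Clc1ccc(C2=NN(C3=NC(c4ccccc4)CS3)C(c3ccc4ccccc4c3)C2)cc1`, has not been measured. It differs from compound 2 in one place: naphthalen-2-yl in place of naphthalen-1-yl on a saturated ring carbon. For the measured compounds named here, no measured pair isolates this change, since compound 1 and compound 2 differ elsewhere as well, so the size of the step is uncertain. Compound 1, which also carries naphthalen-2-yl, gives 1860 nM, and on that basis a move toward a lower number, modest in size, is expected. The step from compound 2 to compound 3 in this assay is estimated at a 2.2-fold lower number from compound 2 to compound 3 (0.34 log units; beyond the scatter). For compound 3 the expected value in this assay is 4500 nM, within a range of 1500 nM to 13000 nM.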

Compound 3, half-maximal inhibitory concentration: 7560 nM
For compound 3 the middle estimate is 1.7-fold (0.23 log units) below the measured one; the measured number falls inside the stated range.
By their numbers in this assay, from the lowest: compound 1; then compounds 3 and 2 (each within the scatter of the next).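

In this assay, naphthalen-2-yl in place of naphthalen-1-yl on the saturated ring carbon gives a 1.3-fold lower number from compound 2 to compound 3 (0.12 log units; within the scatter), so with the 4-chlorophenyl group held fixed, the two naphthyl attachment points cannot be told apart. Chloro in place of methoxy on the aromatic carbon, with naphthalen-2-yl held fixed, gives a 4.1-fold higher number from compound 1 to compound 3 (0.61 log units; beyond the scatter), which places most of the gap between the two earlier compounds at this aromatic substituent and not at the naphthyl attachment point. Nothing in the available data explains either step.

The compounds shown leave open whether the attachment point also makes no difference alongside methoxy, since naphthalen-1-yl appears here only with chloro. They also leave open how an amine or a carboxylic acid in place of chloro would read in this assay.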